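A few compounds are considered here, and "the series" means these few. Any claim that something is new, unique, unknown or untested is made for them only; others in the source may bear on it.

Of the compounds shown here, three have so far been tested in a functional assay on HT-29 cells (Homo sapiens) for cytotoxicity, read by MTT assay, with a stated time of 72 h; on this read-out higher numbers stand for lower toxicity in this test and lower numbers for higher toxicity in this test. Compound 1 `CCCOC(=O)Nc1ccc([Se]C#N)cc1` gives 75400 nM in that test. Compound 2 `CCOC(=O)Nc1ccc([Se][Se]c2ccc(NC(=O)OCC)cc2)cc1` gives 76100 nM, and compound 3 `O=C(Nc1ccc([Se][Se]c2ccc(NC(=O)Oc3ccccc3)cc2)cc1)Oc1ccccc1` gives 70200 nM. The number for compound 1 sits among these with nothing to separate it: its gap to compound 2 and its gap to compound 3 both fall within the usual scatter of repeated measurements, so the three compounds cannot be told apart on this read-out.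

Compound 4 `N#C[Se]c1ccc(NC(=O)Oc2ccccc2)cc1` is still to be measured. It differs from compound 1 in a single place: phenyl in place of propyl on an oxygen next to a carbonyl group. Among the compounds with values here, no measured pair reflects exactly this swap, but compound 2 and compound 3 carry an ethyl and a phenyl on the oxygen next to a carbonyl group of a shared core, and their two values show no difference beyond the scatter. On that basis compound 4 is expected to show only a small step, a 1.0-fold lower number from compound 1 to compound 4 (0.02 log units; within the scatter), with no clear direction in this assay. Compound 4 is therefore estimated at 72000 nM, with a likely range from 30000 nM to 160000 nM.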

Compound 4, concentration lethal to 50% of the cells: 71700 nM
Estimate against measurement, compound 4: 1.0-fold (0.00 log units) above; measured number inside the range.
By their numbers in this assay, from the lowest: compounds 3, 4, 1 and 2 (each within the scatter of the next).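

Within the data shown here, compound 1 and compound 4 are the first measured pair that differ in one place only, so this change can be read directly. In this assay, phenyl in place of propyl on an oxygen next to a carbonyl group gives a 1.1-fold lower number from compound 1 to compound 4 (0.02 log units; within the scatter); at this position, a propyl chain of 3 carbons can give way to a six-membered aromatic ring of 6 carbons with no difference that stands out from the scatter. Nothing measured here offers an explanation for this result.

As far as these compounds go, it remains open whether any group at this oxygen can move the number beyond the scatter. A longer chain, or a chain ending in an amine or a carboxylic acid, would test this position with groups quite unlike propyl and phenyl.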